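Adding a Methyl to a Chain in a Receptor Binding Series

The source may report more compounds than this note shows. Statements on the series, on what has been measured and on what is new or still open speak of the compounds shown alone.

Compound 1, `CCCCCc1cc(C(C)=O)c(O)cc1OCCCCC#N`: 14%
Compound 2, `CCCCCCc1cc(C(C)=O)c(O)cc1OCCCCC#N`: 13%
Compound 3, `C=CCc1cc(C(C)=O)c(O)cc1OCCCC`: 8%

The three measured compounds were tested in an assay on isolated protein for binding affinity to leukotriene B4 receptor 1 (Homo sapiens), tested at 1 uM; a lower number here means less inhibition, a higher number more inhibition at the concentration tested (going by the name of the read-out). Compound 2 differs from compound 1 by methyl in place of hydrogen on a saturated chain carbon, five bonds along the chain from an aromatic carbon, and this gave a number 1 percentage points lower from compound 1 to compound 2 (within the scatter). Compound 4, `C=CCc1cc(C(C)=O)c(O)cc1OCCCCC`, is not yet measured; it differs from compound 3 by methyl in place of hydrogen on a saturated chain carbon, four bonds along the chain from an oxygen on an aromatic ring. Among the compounds with values here, this is the same kind of change as the one from compound 1 to compound 2, though the place differs: five bonds along the chain from an aromatic carbon there, four bonds along the chain from an oxygen on an aromatic ring here. The difference between the two cores is not broken down here. Because compound 1 to compound 2 gave a number 1 percentage points lower from compound 1 to compound 2 (within the scatter), the step from compound 3 to compound 4 is expected to be no change at the digits printed from compound 3 to compound 4 (within the scatter). Compound 4 is therefore estimated at 8%, between 0% and 20%.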

Compound 4, a percentage reported as inhibition, at one concentration (the size of the read-out at that concentration, not a potency): 23%
Beside the measured number, compound 4's estimate is 15 percentage points below it; measured number above the stated range.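

In this assay the added methyl gave a number 15 percentage points higher from compound 3 to compound 4 (beyond the scatter). The same change therefore did not carry over from one core to the other with the same size: the same change on two cores in this assay, a number 1 percentage points lower (within the scatter) from compound 1 to compound 2 and a number 15 percentage points higher (beyond the scatter) from compound 3 to compound 4, 16 percentage points apart, beyond the scatter of two such steps. This is a single pair of steps, and it does not show whether the gap comes from the cores themselves or from the different places the methyl occupies, so it gives no rule for other cores in the series.

The compounds shown leave open whether a longer chain would change the number further on the core of compound 4. They also leave open how an amine or a carboxylic acid in place of this methyl would compare.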